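A few compounds are considered here, and "the series" means these few. Any claim that something is new, unique, unknown or untested is made for them only; others in the source may bear on it.

Measured compounds in an ADME assay on tissue (CCRF-CEM cells, Homo sapiens) for pharmacokinetics, read by HPLC; a lower number here means that the compound disappears faster, a higher number that the compound lasts longer:

compound 1, `CCCCCCCCCCCCCCCCCC(=O)Oc1ccc(COP(=O)(OCc2ccc(C(=O)CCCCCCCCCCCCCCCCC)cc2)OP(=O)(O)OP(=O)(O)OC[C@@H]2C=C[C@H](n3cc(C)c(=O)[nH]c3=O)O2)cc1` — 2.1 h
compound 2, `CCCCCCCCCCCCCCCCCC(=O)c1ccc(COP(=O)(O)OP(=O)(O)OP(=O)(O)OC[C@@H]2C=C[C@H](n3cc(C)c(=O)[nH]c3=O)O2)cc1` — > 30 h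
compound 3, `CCCCCCCCCC(=O)c1ccc(COP(=O)(O)OP(=O)(O)OP(=O)(O)OC[C@H]2O[C@@H](n3cc(C)c(=O)[nH]c3=O)C[C@@H]2O)cc1` — > 30 h

Compound 1 gives a number in this assay, 2.1 h. For compound 2 the value > 30 h is a limit of this assay, not a number. For compound 3 the value > 30 h is likewise a limit. Among the measured compounds shown here, compound 2 therefore stands at the limit of > 30 h in this assay, at which 2 of the 3 values shown sit, together with compound 3, and compound 1 is the one value that falls as a number.

Compound 4, `CCCCCCCCCC(=O)c1ccc(COP(=O)(O)OP(=O)(O)OP(=O)(O)OC[C@@H]2C=C[C@H](n3cc(C)c(=O)[nH]c3=O)O2)cc1`, is not yet measured. It differs from compound 2 by hydrogen in place of octyl on a saturated chain carbon, nine bonds along the chain from a carbonyl carbon; the same difference, cut one bond further out, reads nonyl to methyl. Compound 3 carries this same nonyl-carbonyl chain on a different sugar and also sits at the limit, so no step beyond the scatter is expected from compound 2 to compound 4 in this assay, and compound 4 is expected to report a limit too. The expected step that the limit leaves unreadable from compound 2 to compound 4 is estimated as flat. Compound 4 is estimated at 35 h, within 15 h to 60 h.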

Compound 4, half-life: > 30 h
Compound 4 gave a limit, no number (the forecaster's own chance of this, stated with the estimate: 70%); the middle value is on the limit's open side.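

Compound 4 gives > 30 h in this assay, a limit and not a number. Among the compounds shown here, compound 2 also sits at a limit, so no step between compound 2 and compound 4 can be read. The compounds shown leave open whether hydrogen in place of octyl changes the half-life at all.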